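A few compounds are considered here, and "the series" means these few. Any claim that something is new, unique, unknown or untested is made for them only; others in the source may bear on it.

Measured so far:
compound 1, `CNC(=O)c1cc(C(=O)NCCCC2CNCCO2)cn(Cc2ccccc2)c1=O`: >= 194 ug/mL
compound 2, `CNC(=O)c1cc(C(=O)NC2CCC2)cn(Cc2cccnc2)c1=O`: >= 99 ug/mL

In a physicochemical assay for solubility (on this read-out lower numbers stand for lower solubility and higher numbers for higher solubility), compound 1 gives >= 194 ug/mL, and this is a limit of the assay rather than a number. Compound 1 thus sits at the limit of >= 194 ug/mL in this assay, at which 1 of the 2 values shown sits. Compound 2 in this assay gives >= 99 ug/mL, again a limit and not a number. Compound 2 sits at the limit of >= 99 ug/mL in this assay, at which 1 of the 2 values shown sits. For the measured compounds named here, neither value places a compound at a definite point, and the two compounds share no single-point structural relation, so no measured step can be drawn between them.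

Compound 3, `CNC(=O)c1cc(C(=O)NCCO)cn(Cc2ccccc2)c1=O`, has not yet been measured in this assay. Against compound 1 the difference is hydroxy in place of (morpholin-2-yl)methyl on a saturated chain carbon, two bonds along the chain from an amide-type nitrogen. With compound 1 known only as a limit, the step of an at least 1.1-fold lower number from compound 1 to compound 3 (0.05 log units; that floor lies within the scatter) is expected to stay within the usual scatter, with no clear direction, and it may again end at a limit. For compound 3 in this assay the expected value is 170 ug/mL, with a range from 60 ug/mL to 400 ug/mL.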

Compound 3, solubility: >= 140 ug/mL
Compound 3 gave a limit, no number (the forecaster's own chance of this, stated with the estimate: 55%); the middle value lies beyond the limit too.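

No step can be read from compound 1 to compound 3 in this assay, since both results are limits of the assay rather than numbers. The compounds shown leave open whether hydroxy in place of (morpholin-2-yl)methyl changes the read-out at all, and where compound 1, compound 2 and compound 3 lie beyond their limits.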